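Hydroxyphenyl placement across a three-aryl series

The source may hold more compounds than are shown below. What is called first, only, known or untested is meant among the compounds shown, and "the series" means these compounds.

Compound 1 `Oc1ccccc1-c1cc(-c2cccc(F)c2)cc(-c2ccccc2O)n1` gives > 50000 nM in a functional assay on DU-145 cells (Homo sapiens) for inhibition (on this read-out higher numbers stand for weaker inhibition and lower numbers for stronger inhibition), a limit of the assay and not a number.
Compound 2 `Oc1ccc(-c2cc(-c3cccc(F)c3)cc(-c3ccccc3O)n2)cc1` gives > 50000 nM in this assay, again a limit.
Compound 3 `Oc1ccc(-c2cc(-c3ccc(F)cc3)cc(-c3ccccc3O)n2)cc1` gives > 50000 nM in this assay, also a limit.

Compound 2 thus stands at the limit, as do the other two: the limit of > 50000 nM in this assay, at which 3 of the 3 values shown sit. The steps a step that the two limits leave unreadable from compound 1 to compound 2 and a step that the two limits leave unreadable from compound 2 to compound 3 cannot be read for size. Compound 4 `Oc1ccc(-c2cc(-c3cccc(F)c3)cc(-c3ccc(O)cc3)n2)cc1` differs from compound 2 by 4-hydroxyphenyl in place of 2-hydroxyphenyl on an aromatic carbon. Among the measured compounds shown here, the one measured step that also relocates a hydroxyphenyl group, from compound 1 to compound 2, gave no readable size, so nothing measured guides this step. The step expected here is a step that the limit leaves unreadable from compound 2 to compound 4, nominal only, with compound 4 most likely remaining at the limit. The estimate for compound 4 is 60000 nM, between 20000 nM and 200000 nM.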

Compound 4, half-maximal inhibitory concentration: 9290 nM
Compound 4: the middle estimate sits 6.5-fold (0.81 log units) above what was measured; the measured number lies below the stated range.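

Placing 4-hydroxyphenyl rather than 2-hydroxyphenyl on the aromatic carbon next to the ring nitrogen gives an at least 5.3-fold lower number from compound 2 to compound 4 (0.73 log units; beyond the scatter) in this assay, although the two groups match in every count of atoms, donors and acceptors. Among the compounds shown here, the earlier steps cannot be read, so this is the first sign that the position responds to where the hydroxyl sits on the phenyl. Compound 4 alone leaves the limit: the limit of > 50000 nM in this assay, at which 3 of the 4 values shown sit.

On these data alone, whether an amine or a carboxylic acid in place of that hydroxyl keeps the gain remains open. Also open, as far as these compounds go, is whether the same change holds with the 4-fluorophenyl group of compound 3.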